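A few compounds are considered here, and "the series" means these few. Any claim that something is new, unique, unknown or untested is made for them only; others in the source may bear on it.

In a functional assay on MCF7 cells (Homo sapiens) for cytotoxicity, read by MTT assay, with a stated time of 72 h, tested at 10 uM (on this read-out higher numbers stand for more inhibition of growth at the one concentration tested and lower numbers for less inhibition of growth), compound 1 `N/C(=N\NC(=S)N1CCCCC1)c1ccccn1` gives 53.1%. Compound 3 `N/C(=N\NC(=S)N1CCCC1)c1ccccn1` has a core that differs from that of compound 1 by piperidin-1-yl in place of pyrrolidin-1-yl on a thiocarbonyl carbon; in this assay compound 3 gives 51.7%, and a number 1.4 percentage points lower from compound 1 to compound 3 (within the scatter). Compound 2 `Cc1cccc(/C(N)=N/NC(=S)N2CCCC2)n1` gives 38.2%; the change from compound 3 to compound 2 is methyl in place of hydrogen on an aromatic carbon, and a number 13.5 percentage points lower from compound 3 to compound 2 (beyond the scatter).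

Compound 4 `Cc1ccnc(/C(N)=N/NC(=S)N2CCCCC2)c1` has not yet been measured. It differs from compound 1 by methyl in place of hydrogen on an aromatic carbon. This is the same kind of change as from compound 3 to compound 2, but not the same: in compound 2 the methyl sits next to the ring nitrogen, in compound 4 it sits opposite the ring nitrogen, both meta to a large group. The expected step is a number 11.1 percentage points lower from compound 1 to compound 4 (beyond the scatter), resting on the modest lowering seen from compound 3 to compound 2, with added uncertainty from the different place. Compound 4 is estimated to give 42%, expected between 28% and 56%.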

Compound 4, percent growth inhibition at one concentration: 40.7%
Beside the measured number, compound 4's estimate is 1.3 percentage points above it, and the stated range covers the measured number.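

In this assay, methyl in place of hydrogen on an aromatic carbon of the core of compound 1 gives a number 12.4 percentage points lower from compound 1 to compound 4 (beyond the scatter), and the same change has now been seen on two cores: the same change on two cores in this assay, a number 13.5 percentage points lower (beyond the scatter) from compound 3 to compound 2 and a number 12.4 percentage points lower (beyond the scatter) from compound 1 to compound 4, 1.1 percentage points apart, within the scatter of two such steps. In this small series, then, the lowering carries over from the pyrrolidin-1-yl core to the piperidin-1-yl core, even though the methyl of compound 4 sits opposite the ring nitrogen and that of compound 2 sits at another place. Going by these compounds alone, this rests on only two pairs at one concentration, and it does not show why the number falls or whether the step would hold on other cores.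

As far as these compounds go, it remains open whether an ethyl, a methoxy or an amine on that aromatic carbon would give a similar step.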